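The compounds below may be only part of what the source reports. "The series", "measured", "known", "first", "only" and "open" are said of these compounds alone.

Among the compounds with values here, in a functional assay on HL-60 cells (Homo sapiens) for cytotoxicity, read by WST assay, with a stated time of 48 h (a lower number here means that less compound is needed, a higher number that more compound is needed for the effect), compound 1 `O=C1OC[C@H](Cc2ccccc2)[C@H]1Cc1ccccc1O` gives 83000 nM, the higher of the two numbers measured so far. Compound 2 `CCCCOc1ccccc1C[C@H]1C(=O)OC[C@@H]1Cc1ccccc1` gives 20000 nM. This is a 4.2-fold lower number from compound 1 to compound 2 (0.62 log units; beyond the scatter), the result of placing butyl in place of hydrogen on an oxygen on an aromatic ring.

Compound 3 `O=C1OC[C@H](Cc2ccccc2)[C@H]1Cc1cccc(O)c1` has not yet been measured. It has the same atoms as compound 1, joined differently: 3-hydroxyphenyl in place of 2-hydroxyphenyl on a saturated chain carbon bound to a saturated ring carbon. In words, 3-hydroxyphenyl stands in place of 2-hydroxyphenyl on a saturated chain carbon bound to a saturated ring carbon.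

Within the data shown here, only one measured step is available, and it bears on this change only loosely, since it replaces a hydrogen rather than moving the hydroxyl group. Among the measured compounds shown here, no measured pair shows the effect of such a move. With so little evidence, the expectation is for little or no change beyond the scatter, with a slight lean towards a lower number and a size smaller than a 4.2-fold lower number from compound 1 to compound 2 (0.62 log units; beyond the scatter). The expected step is a 1.3-fold lower number from compound 1 to compound 3 (0.11 log units; within the scatter). For compound 3 the estimated value is 65000 nM, with an expected range of 28000 nM to 150000 nM.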

Compound 3, half-maximal effective concentration: > 100000 nM
Compound 3: no number, only a limit (the forecaster's own chance of this, stated with the estimate: 15%); at least 1.5-fold (0.18 log units) between middle value and limit.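

In this assay compound 3 gives > 100000 nM, which is a limit of the assay and not a number. Within the data shown here, with the same atoms joined differently, 3-hydroxyphenyl in place of 2-hydroxyphenyl on a saturated chain carbon bound to a saturated ring carbon gives an at least 1.2-fold higher number from compound 1 to compound 3 (0.08 log units; that floor lies within the scatter), so this is the first comparison in which the hydroxyl group changes place rather than gaining a substituent on its oxygen, and it shows no fall in the number. The step has only a floor, and that floor lies within the scatter, so the real size of the change cannot be read, and it remains unknown because the value sits at the limit: the limit of > 100000 nM in this assay, at which 1 of the 3 values shown sits.

The compounds shown leave open whether butyl on the oxygen of 3-hydroxyphenyl would lower the number as it does in the step with a 4.2-fold lower number from compound 1 to compound 2 (0.62 log units; beyond the scatter). They also leave open what an amine or a carboxylic acid in place of the hydroxyl group, or a chain longer than butyl on the oxygen, would do in this assay.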